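Phenyl to isopropoxy on the piperidine ring of compound 3

The source may report more compounds than this note shows. Statements on the series, on what has been measured and on what is new or still open speak of the compounds shown alone.

Compound 1 `CC(C(=O)NCc1ccc(C(F)(F)F)nc1Nc1ccccc1)c1ccc(NS(C)(=O)=O)c(F)c1` carries an anilino group on the shared core, and in a functional assay on CHO-K1 cells for antagonist activity at transient receptor potential cation channel subfamily V member 1 (Homo sapiens), read by FLIPR (a higher number here means a weaker inhibitor, a lower number a stronger inhibitor), compound 1 gives 59.6 nM. Compound 2 `CC(C(=O)NCc1ccc(C(F)(F)F)nc1N1CCCCC1C)c1ccc(NS(C)(=O)=O)c(F)c1` gives 2.9 nM, and compound 3 `CC(C(=O)NCc1ccc(C(F)(F)F)nc1N1CCC(c2ccccc2)CC1)c1ccc(NS(C)(=O)=O)c(F)c1` gives 0.6 nM. Compound 3 stands at the lowest number of the three measured, beyond the scatter from both others; the measured steps are a 21-fold lower number from compound 1 to compound 2 (1.31 log units; beyond the scatter), a 99-fold lower number from compound 1 to compound 3 (2.00 log units; beyond the scatter) and a 4.8-fold lower number from compound 2 to compound 3 (0.68 log units; beyond the scatter).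

Compound 4 `CC(C)OC1CCN(c2nc(C(F)(F)F)ccc2CNC(=O)C(C)c2ccc(NS(C)(=O)=O)c(F)c2)CC1` differs from compound 3 by isopropoxy in place of phenyl on a saturated ring carbon. Among the measured compounds shown here, no measured step exchanges one group for another at this position. The step of a 4.8-fold lower number from compound 2 to compound 3 (0.68 log units; beyond the scatter) is the only one that alters the piperidine ring itself and shows that the ring substitution pattern shifted the number by a modest amount; the two steps from compound 1 concern the exchange of anilino for a piperidine and do not bear on a swap within the ring. For the measured compounds named here, the isopropoxy group has no measured precedent, so the expected step of a 3.3-fold higher number from compound 3 to compound 4 (0.52 log units; beyond the scatter) is set as a modest rise in the number, assuming part of the gain recorded in a 4.8-fold lower number from compound 2 to compound 3 (0.68 log units; beyond the scatter) is given back. Compound 4 is therefore estimated at 2 nM, within the range 0.6 nM to 8 nM.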

Compound 4, inhibition constant: 3 nM
Compound 4: middle estimate off by 1.5-fold (0.18 log units), on the low side; measured number inside the range.
By their numbers in this assay, from the lowest: compound 3; then compounds 2 and 4 (each within the scatter of the next); then compound 1.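

Among the compounds shown here, the exchange of phenyl for isopropoxy on the saturated ring carbon, three ring bonds from the ring nitrogen, gives the first direct reading at this position, and the step is modest but beyond the scatter (a 5.0-fold higher number from compound 3 to compound 4 (0.70 log units; beyond the scatter)). The six-membered aromatic ring of carbon can therefore leave this position with only that cost, and the 4-isopropoxypiperidin-1-yl group keeps nearly all of the large gain over the anilino group (a 20-fold lower number from compound 1 to compound 4 (1.30 log units; beyond the scatter)), while it cannot be told apart from the 2-methylpiperidin-1-yl group (a 1.0-fold higher number from compound 2 to compound 4 (0.01 log units; within the scatter)). Nothing available explains why the swap moves the number by this amount.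

The compounds shown do not separate the contribution of the ether oxygen from that of the branched carbon chain, a question that a 4-isobutylpiperidin-1-yl or 4-cyclohexylpiperidin-1-yl group would address. From the compounds shown here alone, how far this position tolerates other groups also stays open, for example a hydroxyl, a primary amine, a carboxylic acid or a longer alkoxy chain such as butoxy.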